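A Trifluoromethyl Step from Compound 2

A few compounds are considered here, and "the series" means these few. Any claim that something is new, unique, unknown or untested is made for them only; others in the source may bear on it.

In a physicochemical assay for lipophilicity, read by LC-MS (on this read-out lower numbers stand for lower lipophilicity and higher numbers for higher lipophilicity), compound 1 (`FC(F)(F)c1cccc(N[C@H]2CC[C@@H](Nc3ccnc(C(F)(F)F)n3)CC2)c1`) reads > 5.3 as a limit of the assay and not as a number. Among the measured compounds shown here, compound 2 (`FC(F)(F)c1nccc(N[C@H]2CC[C@@H](Nc3ccc4nncn4n3)CC2)n1`) gives 1.7 as the only true number so far, and its standing cannot be expressed as a measured step.

Compound 3 (`FC(F)(F)c1nccc(N[C@H]2CC[C@@H](Nc3ccc4nnc(C(F)(F)F)n4n3)CC2)n1`) departs from compound 2 by a single substitution (trifluoromethyl in place of hydrogen on an aromatic carbon). It has trifluoromethyl in place of hydrogen on an aromatic carbon, on a five-membered aromatic ring with 3 nitrogen, part of a fused or bridged system of two rings, and between two ring nitrogen atoms. For the measured compounds named here, no measured pair in this set shows that substitution, so the expectation rests on the structural change alone, starting from compound 2 at 1.7 on this scale.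

An upward step in this assay is expected, larger than the usual scatter of repeated measurements. The estimated change is a number 1.00 log units higher from compound 2 to compound 3 (beyond the scatter) on that reasoning. For compound 3 the expected value is 2.7 with an estimated range from 2.2 to 3.3 for the coming measurement.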

Compound 3, distribution coefficient: 3.8
Compound 3: the middle estimate sits 1.10 log units below what was measured; measured number outside the range, above it.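

The step of a number 2.10 log units higher from compound 2 to compound 3 (beyond the scatter) gives this place, on an aromatic carbon of the five-membered aromatic ring with 3 nitrogen, its first measured reading in this assay for trifluoromethyl in place of hydrogen. Among the compounds shown here, the earlier compounds offered no pair differing in one place, so this is the first single change that can be read in the set, and it is a large step for a group of 4 heavy atoms with no hydrogen-bond donors or acceptors. Both ends of the step are true numbers and neither compound stands at the limit of the assay, so its full size can be read: the limit of > 5.3 in this assay, at which 1 of the 3 values shown sits.

One pair cannot tell whether a step of this size belongs to this place or would follow trifluoromethyl to other positions on the core, since the same change appears nowhere else among these compounds. The compounds shown also leave open how other groups on this aromatic carbon would read, such as a methyl group, a chlorine atom or an amine, and so whether the step tracks the size of the entering group or is particular to trifluoromethyl.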